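The source may report more compounds than this note shows. Statements on the series, on what has been measured and on what is new or still open speak of the compounds shown alone.

Of the compounds shown here, three that share one core have been measured in an assay on isolated protein for inhibition of ubiquitin carboxyl-terminal hydrolase 7 (Homo sapiens), with stated times of 30 min and 2 h; on this read-out higher numbers stand for weaker inhibition and lower numbers for stronger inhibition. Compound 1, `Cn1nc2c(=O)n(CC3(O)CCN(Cc4ccc(-c5ccco5)cc4Cl)CC3)cnc2c1-c1ccc(CNS(C)(=O)=O)cc1`, gives 65.3 nM in this assay. Compound 2, `Cn1nc2c(=O)n(CC3(O)CCN(Cc4ccc(-c5ccco5)cc4Cl)CC3)cnc2c1-c1ccc(F)cc1`, gives 64.5 nM in this assay, and the step of a 1.0-fold lower number from compound 1 to compound 2 (0.01 log units; within the scatter) lies within the scatter. Compound 3, `Cn1nc2c(=O)n(CC3(O)CCN(Cc4ccc(-c5ccco5)cc4Cl)CC3)cnc2c1-c1ccc(CN)cc1`, gives 18.1 nM in this assay and stands lowest of the three numbers, set apart from both of the others by steps beyond the scatter, namely a 3.6-fold lower number from compound 1 to compound 3 (0.56 log units; beyond the scatter) and a 3.6-fold lower number from compound 2 to compound 3 (0.55 log units; beyond the scatter).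

Compound 4, `Cn1nc2c(=O)n(CC3(O)CCN(Cc4ccc(-c5ccco5)cc4Cl)CC3)cnc2c1-c1ccc(Cl)cc1`, has not yet been measured. It differs from compound 3 by chloro in place of aminomethyl on an aromatic carbon. Within the data shown here, two measured steps bear on this change. The step of a 3.6-fold lower number from compound 2 to compound 3 (0.55 log units; beyond the scatter) shows that putting aminomethyl in place of fluoro lowered the number, so taking aminomethyl away again in favour of chloro is expected to undo most of that step. The step of a 1.0-fold lower number from compound 1 to compound 2 (0.01 log units; within the scatter) shows that fluoro and (methanesulfonamido)methyl gave numbers within the scatter of each other, so the fluoro-bearing compound 2 is taken as the closest guide for a chloro analogue. Compound 4 is therefore expected to return to roughly the level of compound 2, a step of a 3.3-fold higher number from compound 3 to compound 4 (0.52 log units; beyond the scatter). The estimate for compound 4 in this assay is 60 nM, with a range from 25 nM to 150 nM.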

Compound 4, half-maximal inhibitory concentration: 143 nM
Beside the measured number, compound 4's estimate is 2.4-fold (0.38 log units) below it; measured number inside the range.
By their numbers in this assay, from the lowest: compound 3; then compounds 2 and 1 (each within the scatter of the next); then compound 4.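

Compound 4 shows that, on this aromatic carbon para to a large group, the groups other than aminomethyl do not all sit at one level in this assay: the measured steps are a 2.2-fold higher number from compound 2 to compound 4 (0.35 log units; beyond the scatter) and a 2.2-fold higher number from compound 1 to compound 4 (0.34 log units; beyond the scatter), both beyond the scatter, although fluoro and (methanesulfonamido)methyl themselves lie within the scatter of each other. The exchange of aminomethyl for chloro is also the largest step in the series, a 7.9-fold higher number from compound 3 to compound 4 (0.90 log units; beyond the scatter), which is larger than either step that had separated compound 3 from compound 1 and compound 2, and it leaves compound 3 lowest of the four by steps beyond the scatter. No measurement given here accounts for the difference between chloro and fluoro or for the low number of compound 3.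

With only fluoro and chloro among the halogens, the compounds shown cannot say whether the number keeps rising along a series that continues with bromo, or how a methyl or methoxy group would compare at this place. They also leave open whether the low number of compound 3 would hold with a hydroxymethyl group, a dimethylaminomethyl group or the longer 2-aminoethyl chain in place of aminomethyl.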